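Hydroxymethyl on the Phenyl of Compound 1

The compounds below may be only part of what the source reports. "The series", "measured", "known", "first", "only" and "open" are said of these compounds alone.

Compound 1 `Fc1ccc(C2(c3ccc(F)cc3)CNC(c3ccccc3)=N2)cc1` gives 32 nM in an assay on LM cells for displacement of a labelled ligand from Neuropeptide Y receptor type 5 (Homo sapiens) (on this read-out lower numbers stand for stronger inhibition and higher numbers for weaker inhibition), the highest of the three numbers measured. Compound 3 `Cc1cccc(C2=NC(c3ccc(F)cc3)(c3ccc(F)cc3)CN2)c1` gives 30 nM, and a 1.1-fold lower number from compound 1 to compound 3 (0.03 log units; within the scatter). Compound 2 `O=Cc1cccc(C2=NC(c3ccc(F)cc3)(c3ccc(F)cc3)CN2)c1` gives 8.7 nM, and a 3.7-fold lower number from compound 1 to compound 2 (0.57 log units; beyond the scatter). Compound 4 `OCc1cccc(C2=NC(c3ccc(F)cc3)(c3ccc(F)cc3)CN2)c1` differs from compound 1 by hydroxymethyl in place of hydrogen on an aromatic carbon. Both measured steps bear on this change, since hydroxymethyl shares the carbon of methyl and the oxygen of formyl; methyl left the number unchanged while formyl lowered it modestly, and a 3.4-fold higher number from compound 2 to compound 3 (0.54 log units; beyond the scatter). A modest lowering is therefore expected, a 2.1-fold lower number from compound 1 to compound 4 (0.33 log units; beyond the scatter). Compound 4 is estimated at 15 nM, in the range 5 nM to 45 nM.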

Compound 4, half-maximal inhibitory concentration: 59 nM
Compound 4: the middle estimate sits 3.9-fold (0.59 log units) below what was measured; measured number outside the range, above it.
By their numbers in this assay, from the lowest: compound 2; then compounds 3, 1 and 4 (each within the scatter of the next).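

Hydroxymethyl on the phenyl of compound 1 gives a 1.8-fold higher number from compound 1 to compound 4 (0.27 log units; within the scatter) and hydroxy on the methyl carbon of compound 3 gives a 2.0-fold higher number from compound 3 to compound 4 (0.29 log units; within the scatter) so neither change moves the number beyond the scatter. The oxygen of hydroxymethyl therefore does not reproduce the lower number seen with formyl at this place. The carbonyl compound stands apart, with a 6.8-fold higher number from compound 2 to compound 4 (0.83 log units; beyond the scatter) as the step away from it.

No measurement shown accounts for the formyl result. On these data alone, whether an aminomethyl group or a carboxylic acid at the same place would track formyl or hydroxymethyl stays open.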